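Benzoyl for acetyl on a diaryl urea: an estimate

The source may report more compounds than this note shows. Statements on the series, on what has been measured and on what is new or still open speak of the compounds shown alone.

Measured compounds:
- compound 1 `CC(=O)Nc1cc(NC(=O)Nc2ccccc2Cl)ccc1C`: > 30000 nM
- compound 2 `CC(=O)Nc1cc(NC(=O)Nc2ccc(Cl)nc2)ccc1C`: 1100 nM

On these data alone, in a functional assay on A375P cells (Homo sapiens) for antiproliferative activity (on this read-out higher numbers stand for weaker inhibition and lower numbers for stronger inhibition), compound 1 reaches only the limit of the assay, > 30000 nM, so its true number is unknown. Compound 2 gives 1100 nM in this assay. Among the measured compounds shown here, the one measured step, an at least 27-fold lower number from compound 1 to compound 2 (1.43 log units; beyond the scatter), changes the aryl group on the urea nitrogen and says nothing about the acetamido group.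

Compound 3 `Cc1ccc(NC(=O)Nc2ccccc2Cl)cc1NC(=O)c1ccccc1` differs from compound 1 as follows: phenyl in place of methyl on a carbonyl carbon. The acetamido group becomes a benzamido group while the urea part stays as in compound 1. For the measured compounds named here, no measured step touches this position, so there is no basis in the data for expecting a change beyond the scatter, and the limit of > 30000 nM in this assay, at which 1 of the 2 values shown sits, of compound 1 means even the starting number is not known.

Compound 3 is therefore expected to sit near 30000 nM, with a plausible range from 8000 nM to 100000 nM, and it may again be reported only as a limit. The expected step is a number no higher from compound 1 to compound 3 (the limit leaves the size open).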

Compound 3, half-maximal inhibitory concentration: > 30000 nM
Compound 3 ended at the assay's limit; the forecaster's own chance of this, stated with the estimate: 55%; the middle value sits exactly at the limit.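

Compound 1 and compound 3 both stop at a limit of this assay rather than at a true number, so no step can be read between them: the limit of > 30000 nM in this assay, at which 2 of the 3 values shown sit.

The compounds shown leave open whether phenyl in place of methyl on a carbonyl carbon changes the number at all, including when the 6-chloropyridin-3-yl group of compound 2 is present.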